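Nitro Group Added to a Scaffold Silent in Cytotoxicity

The compounds below may be only part of what the source reports. "The series", "measured", "known", "first", "only" and "open" are said of these compounds alone.

Compound 1 `O=C(N/N=C/c1ccccc1)c1cccnc1` was examined in an ADME assay on Vero cells (Chlorocebus sabaeus) for cytotoxicity, read by microscopy (on this read-out higher numbers stand for lower toxicity in this test and lower numbers for higher toxicity in this test), together with two close relatives. In this assay compound 1 gives > 100 ug/mL and this is a limit of the assay rather than a number. Compound 2 `O=C(N/N=C/c1cccc(Cl)c1)c1cccnc1` gives > 100 ug/mL in this assay and this too is a limit. Compound 3 `O=C(N/N=C/c1ccc(F)cc1)c1cccnc1` gives > 100 ug/mL in this assay and again this is a limit. The step from compound 1 to compound 2 is a step that the two limits leave unreadable from compound 1 to compound 2 and the step from compound 1 to compound 3 is a step that the two limits leave unreadable from compound 1 to compound 3 because all three values sit at the limit of > 100 ug/mL in this assay, at which 3 of the 3 values shown sit, and no size can be read from them.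

Compound 4 `O=C(N/N=C/c1ccccc1[N+](=O)[O-])c1cccnc1` differs from compound 1 in one place: nitro in place of hydrogen on an aromatic carbon. The two measured steps are the only ones that bear on this change, and both are unreadable. What they show is that adding one small group has not carried any compound away from the limit. The step from compound 1 to compound 4 is therefore expected to be a number no higher from compound 1 to compound 4 (the limit leaves the size open) and to stay within the scatter. Compound 4 is expected to give 100 ug/mL with a range from 50 ug/mL to 200 ug/mL in this assay.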

Compound 4, minimum cytotoxic concentration: > 100 ug/mL
Compound 4: only a limit was reported; the forecaster's own chance of this, stated with the estimate: 85%; the middle value lies on the limit itself.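

No size can be read for the change from compound 1 to compound 4, as both results are limits of the assay: the limit of > 100 ug/mL in this assay, at which 4 of the 4 values shown sit.

The compounds shown leave open where compound 1, compound 2, compound 3 and compound 4 truly stand in this assay, and so whether any of these groups changes the result.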